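This account rests on a few compounds, and the source may have more. Where it says the series, first, only, none or still open, it means among the compounds named here.

Measured so far in an ADME assay on L1210 cells (Mus musculus) for inhibition, read by cell counting; on this read-out lower numbers stand for stronger inhibition and higher numbers for weaker inhibition:
Compound 1, `CSc1nc(NCCCCNc2ccnc3cc(Cl)ccc23)c(C#N)c(-c2ccccc2)n1`: 4400 nM
Compound 2, `COc1ccc(-c2nc(SC)nc(NCCCCNc3ccnc4cc(Cl)ccc34)c2C#N)cc1OC`: 18000 nM

Among the two measured compounds, compound 2 stands highest, which on this read-out means the weaker inhibition. Within the data shown here, its only neighbour is compound 1, and the step of a 4.1-fold higher number from compound 1 to compound 2 (0.61 log units; beyond the scatter) lies beyond the usual scatter of the assay.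

Compound 3, `COc1cc(-c2nc(SC)nc(NCCCCNc3ccnc4cc(Cl)ccc34)c2C#N)cc(OC)c1OC`, has not yet been measured. It differs from compound 2 in one place: methoxy in place of hydrogen on an aromatic carbon. Seen one bond further out, the change reads 3,4-dimethoxyphenyl to 3,4,5-trimethoxyphenyl.

Among the measured compounds shown here, only one measured step bears on this change, the one in which methoxy groups were first added to the same ring: a 4.1-fold higher number from compound 1 to compound 2 (0.61 log units; beyond the scatter). The two measured values show that adding methoxy groups to that ring weakened inhibition once; they do not show whether a third methoxy moves the number again. A further modest rise, or no step beyond the scatter, is therefore expected. The expected step is a 1.4-fold higher number from compound 2 to compound 3 (0.14 log units; within the scatter). Compound 3 is expected to give about 25000 nM, within a range from 9000 nM to 70000 nM.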

Compound 3, half-maximal inhibitory concentration: 3800 nM
Compound 3: middle estimate off by 6.6-fold (0.82 log units), on the high side; the whole stated range lies above it.
By their numbers in this assay, from the lowest: compounds 3 and 1 (each within the scatter of the next); then compound 2.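

In this assay, a methoxy group added to the 3,4-dimethoxyphenyl ring, ortho to a methoxy group and meta to a large group, does not continue the earlier trend. Its step (a 4.7-fold lower number from compound 2 to compound 3 (0.68 log units; beyond the scatter)) is beyond the scatter and runs in the opposite direction to the step from the unsubstituted phenyl (a 4.1-fold higher number from compound 1 to compound 2 (0.61 log units; beyond the scatter)), so the effect of methoxy groups on this ring cannot be read as a simple sum, one group at a time. The 3,4,5-trimethoxyphenyl and phenyl compounds cannot be told apart (a 1.2-fold lower number from compound 1 to compound 3 (0.06 log units; within the scatter)), which is within the scatter and leaves the 3,4-dimethoxyphenyl compound as the only one of the three that stands apart, and nothing available here offers an explanation for this reversal.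

As far as these compounds go, it remains open whether the lower number of compound 3 depends on a methoxy group specifically or would also appear with another group on that aromatic carbon, such as a hydroxyl, a fluorine or an amine. Among these compounds, with only three compounds, it is also open whether a single methoxy group on the phenyl ring would raise the number, lower it or leave it unchanged.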